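Swapping a Furan for a Methylbenzyl Group on the Amide

A few compounds are considered here, and "the series" means these few. Any claim that something is new, unique, unknown or untested is made for them only; others in the source may bear on it.

The measured compounds and their values:
- Compound 1, `CN(C(=O)c1cc2c(Cc3ccccc3)n[nH]c2cc1O)c1ccco1`: 2500 nM
- Compound 2, `CN(Cc1ccccc1Cl)C(=O)c1cc2c(Cc3ccccc3)n[nH]c2cc1O`: 1100 nM
- Compound 3, `CN(Cc1cccc(Cl)c1)C(=O)c1cc2c(Cc3ccccc3)n[nH]c2cc1O`: 5300 nM

All three share one core and differ only in the group carried by the amide-type nitrogen. In a functional assay on A2780 cells (Homo sapiens) for antiproliferative activity, read by resazurin assay, with a stated time of 72 h (a lower number here means a stronger inhibitor, a higher number a weaker inhibitor), compound 1 gives 2500 nM, which places it second highest of the three numbers; it is nearest to compound 3 and furthest from compound 2. Replacing the furan-2-yl of compound 1 gave two different outcomes: a 2.3-fold lower number from compound 1 to compound 2 (0.36 log units; beyond the scatter), whereas a 2.1-fold higher number from compound 1 to compound 3 (0.33 log units; beyond the scatter). The two chlorobenzyl compounds themselves are separated by a 4.8-fold higher number from compound 2 to compound 3 (0.68 log units; beyond the scatter).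

Compound 4, `Cc1ccc(CN(C)C(=O)c2cc3c(Cc4ccccc4)n[nH]c3cc2O)cc1`, is not yet measured. It differs from compound 1 as follows: 4-methylbenzyl in place of furan-2-yl on an amide-type nitrogen. Among the compounds with values here, the relevant measured steps are the two furan-to-benzyl replacements above, which point in opposite directions and are both modest, so the position of a substituent on the benzyl ring clearly matters, and no measured compound carries a 4-methylbenzyl group. The expected step is therefore small, no change at the digits printed from compound 1 to compound 4 (within the scatter), with either direction possible. For compound 4 the estimated value is 2500 nM, within a range from 900 nM to 7000 nM.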

Compound 4, half-maximal inhibitory concentration: 6900 nM
Beside the measured number, compound 4's estimate is 2.8-fold (0.44 log units) below it; measured number inside the range.
By their numbers in this assay, from the lowest: compound 2; then compound 1; then compounds 3 and 4 (each within the scatter of the next).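

In this assay, 4-methylbenzyl on the amide-type nitrogen is a second benzyl-type group that gives a weaker compound than the furan-2-yl one, with a 2.8-fold higher number from compound 1 to compound 4 (0.44 log units; beyond the scatter) and no gain in potency. Compound 3 and compound 4 carry different substituents on the benzyl ring, yet a 1.3-fold higher number from compound 3 to compound 4 (0.11 log units; within the scatter) and the two cannot be told apart here, while a 6.3-fold higher number from compound 2 to compound 4 (0.80 log units; beyond the scatter) and so compound 2, with its 2-chlorobenzyl group, is now the only one of the three benzyl-type compounds stronger than compound 1. Nothing available explains why the 2-chlorobenzyl group stands apart from the other two.

As far as these compounds go, what remains open is whether the gain in compound 2 depends on chlorine itself or on where the substituent sits, a question that 2-methylbenzyl and 4-chlorobenzyl groups on the same nitrogen would address directly. From the compounds shown here alone, it is also open how the plain benzyl group, or a benzyl ring bearing an amine or a carboxylic acid, would compare at this position.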